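Ester or amide on the shared core: level inhibition numbers

The source may report more compounds than this note shows. Statements on the series, on what has been measured and on what is new or still open speak of the compounds shown alone.

Compound 1 `CC1=C(C(=O)OC(C)(C)C)C(c2cccs2)NC(=O)N1`: 7% in an assay on membranes from HeLa cells for displacement of a labelled ligand from adenosine receptor A3 (Homo sapiens), read by scintillation counting, with a stated time of 180 min, tested at 1 uM; a lower number here means less inhibition, a higher number more inhibition at the concentration tested (going by the name of the read-out)
Compound 2 `CC1=C(C(=O)NC(C)C)C(c2cccs2)NC(=O)N1`: 1% in this assay

Among the measured compounds shown here, compound 2 holds the lowest of the two numbers; the only measured step, a number 6 percentage points lower from compound 1 to compound 2 (within the scatter), lies within the scatter. Compound 3 `CC1=C(C(=O)OC2CCCCC2)C(c2cccs2)NC(=O)N1` differs from compound 2 by cyclohexyloxy in place of isopropylamino on a carbonyl carbon, on the same carbonyl carbon that the measured step touched. That step was a number 6 percentage points lower from compound 1 to compound 2 (within the scatter), so reverting to an oxygen-linked group is expected to move this assay by no more than the scatter. The expected step is a number 5 percentage points higher from compound 2 to compound 3 (within the scatter), not beyond the scatter. Compound 3 is therefore estimated at 6%, between -5% and 20%.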

Compound 3, a percentage reported as inhibition, at one concentration (the size of the read-out at that concentration, not a potency): 1%
The estimate for compound 3 lay 5 percentage points above the measured number; low and high end bracket the measured number.
By their numbers in this assay, from the lowest: compounds 2, 3 and 1 (each within the scatter of the next).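

Cyclohexyloxy in place of isopropylamino on the carbonyl carbon gives no change at the digits printed from compound 2 to compound 3 (within the scatter) in this assay and brings a six-membered ring of carbon to this position for the first time. Cyclohexyl in place of tert-butyl on the oxygen gives a number 6 percentage points lower from compound 1 to compound 3 (within the scatter) and so separates the ring from the open-chain ester group no more than the amide was separated from it.

Going by these compounds, whether a carboxylic acid, an amine or a longer chain on this carbonyl carbon would give a number clearly apart from these stays open. Nothing measured here speaks to the reason for these level numbers.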